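The source may hold more compounds than are shown below. What is called first, only, known or untested is meant among the compounds shown, and "the series" means these compounds.

The measured compounds:

compound 1 `O=C1NNC(=O)C2(CSC3=C2C(=O)c2ncccc2C3=O)N1` gives 980 nM
compound 2 `O=C1C2=C(C(=O)c3ncccc31)C1(CS2)NC(=O)N(c2ccc(Cl)cc2)C1=O` gives 2 nM
compound 3 `CCc1ccc(N2C(=O)NC3(CSC4=C3C(=O)c3ncccc3C4=O)C2=O)cc1` gives 5 nM

In a functional assay on HeLa cells (Homo sapiens) for antiproliferative activity, read by MTT assay, with a stated time of 96 h (on this read-out higher numbers stand for weaker inhibition and lower numbers for stronger inhibition), compound 2 has the lowest number of the three; compound 3 is nearest, and compound 1 is furthest away. Compound 4 `CCCCc1ccc(N2C(=O)NC3(CSC4=C3C(=O)c3ncccc3C4=O)C2=O)cc1` differs from compound 2 in one place: butyl in place of chloro on an aromatic carbon. Among the measured compounds shown here, the only measured step that bears on this is a 2.5-fold higher number from compound 2 to compound 3 (0.40 log units; beyond the scatter), in which an alkyl chain also replaced the chloro on the same aromatic carbon. For the measured compounds named here, a longer butyl chain has no measured precedent here, so an expectation rests on that single step. Compound 4 is therefore expected to show a 4.0-fold higher number from compound 2 to compound 4 (0.60 log units; beyond the scatter), a modest rise in the number rather than none. The estimate for compound 4 is 8 nM, within the range 2 nM to 30 nM.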

Compound 4, half-maximal inhibitory concentration: 90 nM
For compound 4 the middle estimate is 11-fold (1.05 log units) below the measured one; the measured number lies above the stated range.
By their numbers in this assay, from the lowest: compound 2; then compound 3; then compound 4; then compound 1.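

The longer chain shows that this position does not take alkyl groups evenly: in this assay there is a 45-fold higher number from compound 2 to compound 4 (1.65 log units; beyond the scatter), far more than the modest change seen with ethyl. Extending ethyl to butyl alone gives an 18-fold higher number from compound 3 to compound 4 (1.26 log units; beyond the scatter), so most of the loss comes with the added chain length rather than with the departure of chloro. Nothing available here accounts for this jump.

The compounds shown leave open whether a propyl chain would fall nearer ethyl or butyl. They also leave open whether a methoxy group or an amine at this place would stay close to compound 2.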